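From chloro to fluoro on compound 1

A few compounds are considered here, and "the series" means these few. Any claim that something is new, unique, unknown or untested is made for them only; others in the source may bear on it.

Among the measured compounds shown here, compound 1 `FC(F)(F)c1cccc(NC(=S)Nc2ccc(Cl)cc2)c1` gives 10000 nM in an ADME assay on BHK cells (Mesocricetus auratus) for cytotoxicity, read by MTT assay, with a stated time of 96 h (a lower number here means that less compound is tolerated, a higher number that more compound is tolerated), and is one of only two compounds measured so far. For the measured compounds named here, compound 2 `O=C(NC(=S)Nc1cccc(C(F)(F)F)c1)[C@H]1C[C@@H]2CC[C@H]1C2` gives 9600 nM in this assay and the two values lie within the scatter of each other, so compound 1 stands level with the only other measured compound.

Compound 3 `Fc1ccc(NC(=S)Nc2cccc(C(F)(F)F)c2)cc1` is still unmeasured. Its difference from compound 1 (fluoro in place of chloro on an aromatic carbon) is fluoro in place of chloro on an aromatic carbon, para to a large group, so that 4-chlorophenyl becomes 4-fluorophenyl.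

Going by the values given here, no measured pair differs in one place, so the data give no direct guide to the size of this swap in this assay for now. The expected 1.2-fold higher number from compound 1 to compound 3 (0.08 log units; within the scatter) is small, with nothing anticipated beyond the scatter and only a slight lean towards more compound tolerated. This expectation starts from compound 1 at 10000 nM as the closest measured structure. For compound 3 the estimated value is 12000 nM with an expected range from 5000 nM to 35000 nM on repeated measurement.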

Compound 3, half-maximal cytotoxic concentration: 26000 nM
Compound 3: middle estimate off by 2.2-fold (0.34 log units), on the low side; low and high end bracket the measured number.
By their numbers in this assay, from the lowest: compounds 2 and 1 (each within the scatter of the next); then compound 3.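

Among the compounds shown here, the swap from 4-chlorophenyl to 4-fluorophenyl provides the first single-place step: in this assay, it reads a 2.6-fold higher number from compound 1 to compound 3 (0.41 log units; beyond the scatter). This shows that the position on the aromatic carbon, para to a large group, responds to a change of one heavy atom, with the number moving beyond the scatter towards more compound tolerated. No measurement in hand bears on the reason for this step, so the result stands as an observation only.

As far as these compounds go, one step gives a size and direction for this single halogen exchange, but it does not show how the position responds more broadly, so the order of hydrogen, bromo, methyl, methoxy, an amine or a carboxylic acid relative to fluoro and chloro remains open. From the compounds shown here alone, it also remains open whether the same change from chloro to fluoro would give a step of similar size and direction on a different aromatic partner in place of the 3-trifluoromethylphenyl group, or at another position on the same ring.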